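This account rests on a few compounds, and the source may have more. Where it says the series, first, only, none or still open, it means among the compounds named here.

Three compounds share one core and differ only in the aromatic group attached to it: compound 1 `c1cn2cc(-c3ccsc3)nc(-c3ccc4ncn(C5CCCCC5)c4c3)c2n1`, compound 2 `Clc1ccc(-c2cn3ccnc3c(-c3ccc4ncn(C5CCCCC5)c4c3)n2)cc1` and compound 3 `COc1ccccc1-c1cn2ccnc2c(-c2ccc3ncn(C4CCCCC4)c3c2)n1`. In a functional assay on CCRF-CEM cells (Homo sapiens) for inhibition, read by sulforhodamine B assay, with a stated time of 48 h, tested at 10 uM (on this read-out lower numbers stand for less inhibition and higher numbers for more inhibition at the one concentration tested (going by the name of the read-out)), compound 1 gives 29.2%, compound 2 gives 11.4% and compound 3 gives 17.4%, so compound 3 stands second highest of the three. Compound 4 `Fc1ccccc1-c1cn2ccnc2c(-c2ccc3ncn(C4CCCCC4)c3c2)n1` differs from compound 3 by one change: fluoro in place of methoxy on an aromatic carbon. The measured steps are a number 17.8 percentage points lower from compound 1 to compound 2 (beyond the scatter), a number 11.8 percentage points lower from compound 1 to compound 3 (beyond the scatter) and a number 6 percentage points higher from compound 2 to compound 3 (within the scatter); compound 2, which also carries a halogen on its phenyl, lies within the scatter of compound 3, so the change to fluoro is expected to move the number little, if at all. Compound 4 is therefore estimated at 14%, between 5% and 25%, an expected step of a number 3.4 percentage points lower from compound 3 to compound 4 (within the scatter).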

Compound 4, a percentage reported as inhibition, at one concentration (the size of the read-out at that concentration, not a potency): 22.5%
Estimate against measurement, compound 4: 8.5 percentage points below; the measured number falls inside the stated range.
By their numbers in this assay, from the lowest: compounds 2, 3, 4 and 1 (each within the scatter of the next, the first and the last beyond it).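

In this assay, fluoro in place of methoxy, on an aromatic carbon ortho to a large group, gives a number 5.1 percentage points higher from compound 3 to compound 4 (within the scatter) and so does not separate the two groups. Among these compounds, the 2-fluorophenyl group does separate from 4-chlorophenyl, with a number 11.1 percentage points higher from compound 2 to compound 4 (beyond the scatter), yet not from thiophen-3-yl, with a number 6.7 percentage points lower from compound 1 to compound 4 (within the scatter), which makes compound 4 the only phenyl compound here within the scatter of compound 1. No measured evidence is available to explain these steps. On these data alone, whether an amine, a carboxylic acid or a longer chain on this phenyl ring would give a similar number remains open.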